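Phenyl to diethylamino: what one measured step suggests

The source may report more compounds than this note shows. Statements on the series, on what has been measured and on what is new or still open speak of the compounds shown alone.

In a functional assay on A549 cells (Homo sapiens) for antiproliferative activity, read by MTT assay, with a stated time of 48 h (a lower number here means a stronger inhibitor, a higher number a weaker inhibitor), compound 1 `COc1ccc(/C=C/c2cc(OC)cc(OC)c2/C=C/C(=O)c2ccc(Cl)cc2)cc1` gives 6.4 ug/mL and compound 2 `COc1ccc(/C=C/c2cc(OC)cc(OC)c2/C=C/C(=O)c2ccc(-c3ccccc3)cc2)cc1` gives 4.6 ug/mL, so compound 2 sits within the usual scatter of compound 1. Compound 3 `CCN(CC)c1ccc(C(=O)/C=C/c2c(/C=C/c3ccc(OC)cc3)cc(OC)cc2OC)cc1` keeps the shared core and alters the same spot as that pair: diethylamino in place of phenyl on an aromatic carbon. This puts diethylamino in place of phenyl on an aromatic carbon, para to a large group. Among the measured compounds shown here, only one measured step bears on this, the exchange of chloro for phenyl at that spot, and it was small: a 1.4-fold lower number from compound 1 to compound 2 (0.14 log units; within the scatter). For the measured compounds named here, no measured compound yet carries diethylamino, so the evidence is thin and no clear direction can be argued. The expected change, a 1.2-fold higher number from compound 2 to compound 3 (0.08 log units; within the scatter), is therefore no step beyond the scatter. For compound 3 the estimated value is 5.5 ug/mL, with an expected range from 2.2 ug/mL to 14 ug/mL.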

Compound 3, half-maximal inhibitory concentration: 5.4 ug/mL
Estimate against measurement, compound 3: 1.0-fold (0.01 log units) above; measured number inside the range.
By their numbers in this assay, from the lowest: compounds 2, 3 and 1 (each within the scatter of the next).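

Diethylamino now joins chloro and phenyl at this position, and in this assay the exchange for phenyl gives a 1.2-fold higher number from compound 2 to compound 3 (0.07 log units; within the scatter), while the exchange for chloro gives a 1.2-fold lower number from compound 1 to compound 3 (0.07 log units; within the scatter). The new step adds something the first pair could not show: replacing a six-membered aromatic ring with an open group that has no ring, contains nitrogen and carries one hydrogen-bond acceptor still leaves the number within the scatter for these three compounds. Nothing measured here explains why such different groups give such close numbers. From the compounds shown here alone, it remains open whether a carboxylic acid, a hydroxyl group or a longer chain at this position would give a step beyond the scatter. The three compounds also leave open whether their closeness holds on any other cell line.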